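Aryl groups on the piperazine nitrogen in the aminothiophene series

The source may hold more compounds than are shown below. What is called first, only, known or untested is meant among the compounds shown, and "the series" means these compounds.

Three compounds with the same core differ only in the group on an amine nitrogen in a ring. Compound 1 `CC(C)N1CCN(Cc2csc(N)c2C(=O)c2ccc(Cl)cc2)CC1` carries an isopropyl there, and in a functional assay on CHO cells with adenosine receptor A1 (Homo sapiens) as the target, read by cAMP accumulation and immunoassay, with a stated time of 6 min, tested at 0.1 uM (on this read-out higher numbers stand for a weaker effect at the one concentration tested and lower numbers for a stronger effect), compound 1 gives 3.6%. Compound 2 `Nc1scc(CN2CCN(c3ccc(Cl)c(C(F)(F)F)c3)CC2)c1C(=O)c1ccc(Cl)cc1` carries 4-chloro-3-(trifluoromethyl)phenyl, and in this assay compound 2 gives -12%. Compound 3 `Nc1scc(CN2CCN(c3cccc(F)c3)CC2)c1C(=O)c1ccc(Cl)cc1` carries 3-fluorophenyl, and in this assay compound 3 gives -37%. Compound 3 has the lowest number of the three: the step of a number 40.6 percentage points lower from compound 1 to compound 3 (beyond the scatter) is the largest shown, the step of a number 25 percentage points lower from compound 2 to compound 3 (beyond the scatter) is smaller, and the step of a number 15.6 percentage points lower from compound 1 to compound 2 (beyond the scatter) is smaller still.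

Compound 4 `Nc1scc(CN2CCN(c3c(F)cc(F)cc3F)CC2)c1C(=O)c1ccc(Cl)cc1` has not been measured. It differs from compound 3 in one place: 2,4,6-trifluorophenyl in place of 3-fluorophenyl on an amine nitrogen in a ring. The measured steps show that each aryl group at this position gives a lower number than isopropyl, and that the 3-fluorophenyl of compound 3 gives a lower number than the more substituted aryl of compound 2. No step compares two fluorinated aryl groups, so the direction of further fluorination is not shown. Compound 4 is therefore expected to stay near compound 3, perhaps somewhat higher as with compound 2 at -12%, a step of a number 12 percentage points higher from compound 3 to compound 4 (beyond the scatter). The estimate for compound 4 in this assay is -25%, within -50% to 0%.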

Compound 4, a percentage reported as activity, at one concentration (the size of the read-out at that concentration, not a potency): -3.9%
Estimate against measurement, compound 4: 21.1 percentage points below, and the stated range covers the measured number.
By their numbers in this assay, from the lowest: compound 3; then compounds 2, 4 and 1 (each within the scatter of the next, the first and the last beyond it).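

Among these compounds, changing the fluorine substitution on the aryl group moves the read-out strongly in this assay: 2,4,6-trifluorophenyl in place of 3-fluorophenyl gives a number 33.1 percentage points higher from compound 3 to compound 4 (beyond the scatter), the first comparison of two fluorinated aryl groups at this position. An aryl group on the ring nitrogen therefore does not by itself give a number lower than isopropyl, since the exchange gives a number 7.5 percentage points lower from compound 1 to compound 4 (within the scatter) and compound 4 goes against the lower numbers seen for the other two aryl groups. The exchange of the two more heavily substituted aryl groups gives a number 8.1 percentage points higher from compound 2 to compound 4 (within the scatter), so compound 3 now stands apart from all the other compounds by steps beyond the scatter, and its low number belongs to 3-fluorophenyl rather than to aryl groups in general.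

Still open, from the compounds shown here alone, is whether the low number of compound 3 would carry over to an unsubstituted phenyl or to a pyridine ring on the same nitrogen. No measurement at hand offers a reason for the difference between the two fluorinated aryl groups.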